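A few compounds are considered here, and "the series" means these few. Any claim that something is new, unique, unknown or untested is made for them only; others in the source may bear on it.

Compound 3 `O=C(O)C1(c2nn(Cc3cn4cc(OCC5CC5)c(Cl)cc4n3)c3ccccc3c2=O)CC1` gives the lowest of the three numbers in a functional assay on CHO cells for antagonist activity at sphingosine 1-phosphate receptor 2 (Homo sapiens), read by calcium flux (on this read-out higher numbers stand for weaker inhibition and lower numbers for stronger inhibition), at 16 nM. Its neighbours are compound 2 `O=C(O)Cc1nn(Cc2cn3cc(OCC4CC4)c(Cl)cc3n2)c2ccccc2c1=O`, which in this assay gives 20 nM, and compound 1 `C[C@@H](C(=O)O)c1nn(Cc2cn3cc(OCC4CC4)c(Cl)cc3n2)c2ccccc2c1=O`, which gives 24 nM; both steps, a 1.3-fold lower number from compound 2 to compound 3 (0.10 log units; within the scatter) and a 1.5-fold lower number from compound 1 to compound 3 (0.18 log units; within the scatter), stay within the scatter. Compound 4 `C[C@H](C(=O)O)c1nn(Cc2cn3cc(OCC4CC4)c(Cl)cc3n2)c2ccccc2c1=O` carries the change (1-carboxyethyl in place of 1-carboxycyclopropyl on an aromatic carbon), so the chain of compound 1 returns with the other stereocentre. The step that bears on it is a 1.5-fold lower number from compound 1 to compound 3 (0.18 log units; within the scatter), run the other way, together with the small step of a 1.2-fold lower number from compound 1 to compound 2 (0.08 log units; within the scatter). Compound 4 is therefore expected to sit close to compound 3, with a step of a 1.4-fold higher number from compound 3 to compound 4 (0.14 log units; within the scatter) that stays within the scatter. For compound 4 the estimate is 22 nM, between 11 nM and 44 nM.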

Compound 4, half-maximal inhibitory concentration: 3.2 nM
The estimate for compound 4 lay 6.9-fold (0.84 log units) above the measured number; measured number below the stated range.
By their numbers in this assay, from the lowest: compound 4; then compounds 3, 2 and 1 (each within the scatter of the next).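

The configuration at this chain carbon now matters, with a 7.5-fold lower number from compound 1 to compound 4 (0.88 log units; beyond the scatter), whereas every earlier change at this place stayed within the scatter. Compound 4 also stands apart from the other two acids, with a 6.3-fold lower number from compound 2 to compound 4 (0.80 log units; beyond the scatter) and a 5.0-fold lower number from compound 3 to compound 4 (0.70 log units; beyond the scatter), so the added methyl goes with a lower number only when drawn S; compound 1, drawn R, stays within the scatter of compound 2. The gap between the two methyl compounds rests on configuration alone: the fact that compounds 1 and 4 differ only in the configuration as drawn. On these data alone, whether an ethyl or hydroxyl group on this carbon would hold the low number remains open, as does whether an amide or tetrazole could replace the carboxylic acid.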